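The source may hold more compounds than are shown below. What is called first, only, known or untested is meant among the compounds shown, and "the series" means these compounds.

Compounds 1 and 2 share one core and differ only in a group on an aromatic carbon. Compound 1 `CCC(COc1cccc(C(F)(F)F)c1)OC(=O)NCc1ccccc1` carries a trifluoromethyl there, and compound 2 `CCC(COc1cccc(C#N)c1)OC(=O)NCc1ccccc1` carries a cyano in place of that trifluoromethyl. In an assay for inhibition of zeta-carotene desaturase, chloroplastic/chromoplastic (Capsicum annuum), using a Dixon plot, with a stated time of 8 h (a higher number here means a weaker inhibitor, a lower number a stronger inhibitor), compound 1 gives only a limit, > 100000 nM. In this assay compound 2 likewise gives only a limit, > 100000 nM. The step from compound 1 to compound 2 is therefore a step that the two limits leave unreadable from compound 1 to compound 2; both values sit at the limit of > 100000 nM in this assay, at which 2 of the 2 values shown sit, so compound 2 stands at the edge of what this assay can report rather than at a measured number. Compound 3 `CCC(COc1c(Cl)cccc1Cl)OC(=O)NCc1ccccc1` differs from compound 2 by 2,6-dichlorophenyl in place of 3-cyanophenyl on an oxygen on a saturated carbon. Among the compounds with values here, no measured step bears on this change, and the single step available is unreadable. Compound 3 is therefore expected to remain at the limit, which means an expected step that the limit leaves unreadable from compound 2 to compound 3. The estimate for compound 3 in this assay is 150000 nM, within 50000 nM to 500000 nM.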

Compound 3, half-maximal inhibitory concentration: > 100000 nM
Compound 3 ended at the assay's limit (the forecaster's own chance of this, stated with the estimate: 80%); the middle value lies beyond the limit too.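

Within the data shown here, compound 2 and compound 3 each give only a limit in this assay and no step between them can be read. The compounds shown leave open whether any change to the shared core would give a measured number in this assay rather than a limit.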